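From methylamino to ethylamino on a shared core

A few compounds are considered here, and "the series" means these few. Any claim that something is new, unique, unknown or untested is made for them only; others in the source may bear on it.

In a functional assay on HCT-8 cells (Homo sapiens) for antiproliferative activity, read by MTT assay, with a stated time of 48 h (a higher number here means a weaker inhibitor, a lower number a stronger inhibitor), compound 1 (`COc1ccc(C(=O)c2ccc(OC)c3c2C=CC(C)(C)O3)c(NC(=O)CO)c1`) reads 630 nM and compound 2 (`COc1ccc(C(=O)c2cc(OC)c(OC)c(OC)c2)c(NC(=O)CO)c1`) reads 120 nM on the same scale. Compound 3 (`CNCC(=O)Nc1cc(OC)ccc1C(=O)c1cc(OC)c(OC)c(OC)c1`) reads 780 nM as well, which lies within the scatter of compound 1 and beyond the scatter of compound 2. Among the compounds with values here, the one measured step on this chain (a 6.5-fold higher number from compound 2 to compound 3 (0.81 log units; beyond the scatter)) put methylamino in place of hydroxy, and it is modest. Compound 4 (`CCNCC(=O)Nc1cc(OC)ccc1C(=O)c1cc(OC)c(OC)c(OC)c1`) has methyl in place of hydrogen on a saturated chain carbon bound to an amine nitrogen, so methylamino becomes ethylamino (methyl in place of hydrogen on a saturated chain carbon bound to an amine nitrogen). Within the data shown here, no measured step covers such a change, so in this assay no step beyond the scatter is expected. The expected change is small (a 1.0-fold higher number from compound 3 to compound 4 (0.01 log units; within the scatter)). Compound 4 is estimated at 800 nM and an expected range of 300 nM to 2000 nM brackets it.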

Compound 4, half-maximal inhibitory concentration: 1560 nM
The estimate for compound 4 lay 2.0-fold (0.29 log units) below the measured number; the range from low to high includes it.
By their numbers in this assay, from the lowest: compound 2; then compounds 1, 3 and 4 (each within the scatter of the next, the first and the last beyond it).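

In this assay, methyl in place of hydrogen on a saturated chain carbon bound to an amine nitrogen gives a 2.0-fold higher number from compound 3 to compound 4 (0.30 log units; within the scatter), so methylamino to ethylamino does not clearly separate the two compounds. Ethylamino in place of hydroxy gives a 13-fold higher number from compound 2 to compound 4 (1.11 log units; beyond the scatter), so the loss seen with methylamino also holds with ethylamino. No evidence at hand explains either step. On these data alone, whether a propylamino group, a dimethylamino group or a carboxylic acid would read closer to the hydroxy compound stays open. So does whether ethylamino would behave alike on the core of compound 1.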